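From Chloro to Methyl at the Assay Limit

The compounds below may be only part of what the source reports. "The series", "measured", "known", "first", "only" and "open" are said of these compounds alone.

In an ADME assay on HEK-293T cells (Homo sapiens) for inhibition, read by CCK-8 assay, with a stated time of 48 h (on this read-out higher numbers stand for weaker inhibition and lower numbers for stronger inhibition), compound 1 (`COc1ccc(S(=O)(=O)Oc2ccccc2/C=C(\C#N)C(=O)Nc2nnc(Cc3cccc4ccccc34)s2)cc1`) gives > 50000 nM as a limit of the assay. Compound 2 (`COc1ccc(S(=O)(=O)Oc2ccccc2/C=C(\C#N)C(=O)Nc2nnc(Cc3ccc(Cl)cc3)s2)cc1`) gives > 50000 nM and this too is only a limit. Among the measured compounds shown here, the numbers so far amount to the limit of > 50000 nM in this assay, at which 2 of the 2 values shown sit, and the one measured step is a step that the two limits leave unreadable from compound 1 to compound 2 with no size to carry forward. Compound 3 (`COc1ccc(S(=O)(=O)Oc2ccccc2/C=C(\C#N)C(=O)Nc2nnc(Cc3ccc(C)cc3)s2)cc1`) has methyl in place of chloro on an aromatic carbon para to a large group. The expected change is a number no higher from compound 2 to compound 3 (the limit leaves the size open) and no step beyond the scatter is anticipated in this assay for it. For compound 3 the estimated value is 50000 nM with 25000 nM to 100000 nM as the expected range.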

Compound 3, half-maximal inhibitory concentration: > 50000 nM
Compound 3: a limit, no number; the forecaster's own chance of this, stated with the estimate: 85%; the middle value lies on the limit itself.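

No step can be read among compound 1, compound 2 and compound 3, since all three stand at one shared assay limit: the limit of > 50000 nM in this assay, at which 3 of the 3 values shown sit.

From the compounds shown here alone, whether the naphthalen-1-yl, 4-chlorophenyl and 4-methylphenyl compounds differ at all, and by how much, stays open.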